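A few compounds are considered here, and "the series" means these few. Any claim that something is new, unique, unknown or untested is made for them only; others in the source may bear on it.

Measured in an ADME assay on liver for metabolic stability, with Liver microsome (Homo sapiens) as the target, read by LC-MS, using microsomes; on this read-out higher numbers stand for fast clearance and lower numbers for slow clearance:
- compound 1 `O=C(NCc1cc(Cl)ccc1-n1cnnn1)[C@@H]1C[C@@H]2C[C@@H]2N1C(=O)[C@H](O)c1cccc(Cl)c1`: > 500 mL.min-1.g-1
- compound 2 `CC(C)(C)C[C@@H](O)C(=O)N1[C@H](C(=O)NCc2cc(Cl)ccc2-n2cnnn2)C[C@@H]2C[C@@H]21`: 40 mL.min-1.g-1

The entry for compound 1 is a limit of the assay, not a number. Among the measured compounds shown here, this leaves compound 2, at 40 mL.min-1.g-1, as the only true number. Compound 3 `O=C(NCc1cc(Cl)ccc1-n1cnnn1)[C@@H]1C[C@@H]2C[C@@H]2N1C(=O)[C@H](O)c1ccccc1F` has 2-fluorophenyl in place of neopentyl on a saturated chain carbon bound to a carbonyl carbon and an oxygen on a saturated carbon. For the measured compounds named here, the one step that bears on this is the large at least 12-fold lower number from compound 1 to compound 2 (1.09 log units; beyond the scatter), where neopentyl replaced 3-chlorophenyl at that same place. Returning a substituted phenyl should therefore reverse part of that drop, and the expected move is a 3.8-fold higher number from compound 2 to compound 3 (0.57 log units; beyond the scatter). For compound 3 the estimated value is 150 mL.min-1.g-1, with an expected range of 50 mL.min-1.g-1 to 500 mL.min-1.g-1.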

Compound 3, intrinsic clearance in microsomes: < 12 mL.min-1.g-1
Compound 3 was reported as a limit (the forecaster's own chance of this, stated with the estimate: 15%); middle value at least 12-fold (1.09 log units) away from the limit.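

In this assay, a phenyl ring at this place does not by itself bring fast clearance: compound 3, with 2-fluorophenyl, gives < 12 mL.min-1.g-1, which is a limit of the assay. Neopentyl therefore does not always beat an aromatic ring here, as replacing it gives an at least 3.3-fold lower number from compound 2 to compound 3 (0.52 log units; beyond the scatter). The choice of substituted phenyl matters greatly, with an at least 41-fold lower number from compound 1 to compound 3 (1.61 log units; beyond the scatter).

The compounds shown leave open whether the change of halogen or its place on the ring accounts for this gap. As far as these compounds go, how an unsubstituted phenyl or a pyridine ring would read here also remains open.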